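A few compounds are considered here, and "the series" means these few. Any claim that something is new, unique, unknown or untested is made for them only; others in the source may bear on it.

Series notes, compound 3 to compound 4.

Among the measured compounds shown here, the shared core carries an amino group and an aryl ether; the three measured members differ only in the group on the ether oxygen. Compound 1 `CC1CCCCC1Oc1cccc2ccc(N)nc12` gives 1330 nM in a functional assay on IMR-32 cells with melanin-concentrating hormone receptor 1 (Homo sapiens) as the target, read by fluorescence; on this read-out lower numbers stand for stronger inhibition and higher numbers for weaker inhibition. Compound 2 `Nc1ccc2cccc(OC3CCCCCC3)c2n1` gives 3480 nM in this assay. Compound 3 `CCCC(C)Oc1cccc2ccc(N)nc12` gives 860 nM in this assay.

Compound 3 stands at the lowest of the three numbers. Its nearest neighbour is compound 1, whose number sits within the usual scatter of compound 3, so no order between these two can be read. Compound 2 lies furthest away, with a number beyond the scatter above compound 3.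

Compound 4 `Nc1ccc2cccc(OCC3CCOC3)c2n1` has not been measured in this assay. It differs from compound 3 in one place: (oxolan-3-yl)methyl in place of 1-methylbutyl on an oxygen on an aromatic ring. For the measured compounds named here, no pair of measured compounds shows a step of this kind, so there is no measured precedent for it. Given that the one ring-bearing ether group measured so far, in compound 2, returns the highest number, the step from compound 3 to compound 4 is expected to run upward, by a 1.9-fold higher number from compound 3 to compound 4 (0.27 log units; within the scatter), though it may stay within the scatter. Compound 4 is therefore estimated at 1600 nM in this assay, with a range from 500 nM to 5000 nM.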

Compound 4, half-maximal inhibitory concentration: 6240 nM
Estimate against measurement, compound 4: 3.9-fold (0.59 log units) below; measured number outside the range, above it.
By their numbers in this assay, from the lowest: compounds 3 and 1 (each within the scatter of the next); then compounds 2 and 4 (each within the scatter of the next).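

In this assay, the group on this oxygen turns out to be sensitive to more than its size: a 7.3-fold higher number from compound 3 to compound 4 (0.86 log units; beyond the scatter) goes with a swap of 1-methylbutyl, which has no ring and 0 hydrogen-bond acceptors, for (oxolan-3-yl)methyl, which has one five-membered non-aromatic ring and 1 hydrogen-bond acceptor. Compound 4 now sits with compound 2 in the upper pair, within the scatter of each other, but a ring alone does not set that level, since compound 1 also carries a ring on this oxygen and stays within the scatter of compound 3. Nothing at hand accounts for the size of this step.

The compounds shown leave open whether the step follows the ring oxygen, the ring itself or the extra carbon linking the ring to the ether oxygen, as all of these change together in compound 4. A cyclopentylmethyl group on the same oxygen, the all-carbon counterpart of (oxolan-3-yl)methyl, would separate the ring oxygen from the rest, and a longer open chain would show how far the acyclic side extends.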